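Trading an Anilide for a Hydroxypyrrolidine Amide

This account rests on a few compounds, and the source may have more. Where it says the series, first, only, none or still open, it means among the compounds named here.

For the measured compounds named here, compound 2 `NCc1cc(Oc2cccc(C(=O)Nc3ccccc3)c2)nc(C(F)(F)F)c1` gives the higher of the two numbers measured so far in an ADME assay on the whole organism (lung, Mus musculus) for pharmacokinetics, read by LC-MS, at a dose of 30 mg/kg by the oral route (a lower number here means less compound in the circulation, a higher number more compound in the circulation at the dose given), namely 10300 nM. Going by the values given here, compound 1 `NCc1cc(Oc2cccc(C(=O)NC[C@@H](O)CO)c2)nc(C(F)(F)F)c1` gives 1920 nM, and the only measured step is a 5.4-fold higher number from compound 1 to compound 2 (0.73 log units; beyond the scatter), where phenyl replaced 2,3-dihydroxypropyl. Compound 3 `NCc1cc(Oc2cccc(C(=O)N3CC[C@@H](O)C3)c2)nc(C(F)(F)F)c1` differs from compound 2 by 3-hydroxypyrrolidin-1-yl in place of anilino on a carbonyl carbon. That one step moves in the opposite direction to this change, a phenyl leaving and a 3-hydroxypyrrolidin-1-yl entering, so a lower number of similar size is expected, about a 3.4-fold lower number from compound 2 to compound 3 (0.54 log units; beyond the scatter). Compound 3 is therefore expected to give 3000 nM, with a likely range of 1000 nM to 9000 nM.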

Compound 3, maximal plasma concentration: 9130 nM
Estimate against measurement, compound 3: 3.0-fold (0.48 log units) below, outside the stated range (above it).
By their numbers in this assay, from the lowest: compound 1; then compounds 3 and 2 (each within the scatter of the next).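

In this assay there is only a 1.1-fold lower number from compound 2 to compound 3 (0.05 log units; within the scatter), so on this carbonyl carbon an aromatic ring is not required for a high number. Oxygen in the group does not by itself go with a low number either: 3-hydroxypyrrolidin-1-yl in place of (2,3-dihydroxypropyl)amino gives a 4.8-fold higher number from compound 1 to compound 3 (0.68 log units; beyond the scatter) on the same core. Nothing available explains these numbers. Still open, going by these compounds, is what a plain pyrrolidine amide or a morpholine amide would give, and so whether the hydroxyl group itself matters.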